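Pyrazole hydroquinone to quinone swap, growth inhibition

The source may hold more compounds than are shown below. What is called first, only, known or untested is meant among the compounds shown, and "the series" means these compounds.

Measured so far:
compound 1 `NS(=O)(=O)c1ccc(-n2nc(-c3ccc(Cl)cc3)cc2-c2cc(O)ccc2O)cc1`: 29800 nM
compound 2 `CC(=O)NS(=O)(=O)c1ccc(-n2nc(-c3ccccc3)cc2-c2cc(O)ccc2O)cc1`: 100000 nM
compound 3 `NS(=O)(=O)c1ccc(-n2nc(-c3ccc(Cl)cc3)cc2C2=CC(=O)C=CC2=O)cc1`: 71900 nM

In a functional assay on cells (Cancer cell lines, Homo sapiens) for cytotoxicity, read by sulforhodamine B assay, with a stated time of 48 h (on this read-out higher numbers stand for weaker inhibition of growth and lower numbers for stronger inhibition of growth), compound 1 gives 29800 nM, compound 3 gives 71900 nM and compound 2 gives 100000 nM. The change from compound 1 to compound 3 is a group of 8 heavy atoms (6 carbon, 2 oxygen; one six-membered non-aromatic ring of carbon only) in place of a group of 8 heavy atoms (6 carbon, 2 oxygen; one six-membered aromatic ring of carbon only), on an aromatic carbon, and it gave a 2.4-fold higher number from compound 1 to compound 3 (0.38 log units; beyond the scatter). Compound 4 `CC(=O)NS(=O)(=O)c1ccc(-n2nc(-c3ccccc3)cc2C2=CC(=O)C=CC2=O)cc1` is not yet measured. From compound 2 it differs by a group of 8 heavy atoms (6 carbon, 2 oxygen; one six-membered non-aromatic ring of carbon only) in place of a group of 8 heavy atoms (6 carbon, 2 oxygen; one six-membered aromatic ring of carbon only), on an aromatic carbon, the same kind of change, though around the place the ring atom here bears a large group and a phenyl group rather than a 4-sulfamoylphenyl group and a 4-chlorophenyl group. The difference between the cores of compound 1 and compound 2 is not broken down here. For compound 4 a step of about a 2.0-fold higher number from compound 2 to compound 4 (0.30 log units; within the scatter) in this assay is expected, resting on the modest step seen for the same kind of change from compound 1 to compound 3. The estimate for compound 4 is 200000 nM, between 80000 nM and 500000 nM.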

Compound 4, concentration for total growth inhibition: 100000 nM
The estimate for compound 4 lay 2.0-fold (0.30 log units) above the measured number; low and high end bracket the measured number.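

In this assay, replacing 2,5-dihydroxyphenyl with the non-aromatic ring gave no change at the digits printed from compound 2 to compound 4 (within the scatter). Set beside the same change on the core of compound 1, the two steps do not differ beyond the scatter: the same change on two cores in this assay, a 2.4-fold higher number (0.38 log units; beyond the scatter) from compound 1 to compound 3 and no change at the digits printed (within the scatter) from compound 2 to compound 4, 2.4-fold (0.38 log units) apart, within the scatter of two such steps. The change therefore carries across these two cores without a step that can be told apart, but two pairs show neither a general rule for the series nor how each difference between the cores contributes.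

The compounds shown do not separate the chlorine on the phenyl group from the acetyl group on the sulfonamide nitrogen. Also open, going by these compounds, is how the change compares with a methyl ether of each hydroxyl on the 2,5-dihydroxyphenyl ring.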